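A few compounds are considered here, and "the series" means these few. Any claim that something is new, unique, unknown or untested is made for them only; others in the source may bear on it.

Measured in an ADME assay on HepG2 cells (Homo sapiens) for cytotoxicity, read by MTT assay, with a stated time of 72 h; on this read-out lower numbers stand for higher toxicity in this test and higher numbers for lower toxicity in this test:
- Compound 1 `CCCNc1nc2cc(-c3ccc(C)cc3)sc2c(=O)[nH]1`: > 62500 nM (a limit of the assay, not a number)
- Compound 2 `CCCCCNc1nc2cc(-c3ccc(C)cc3)sc2c(=O)[nH]1`: 4200 nM
- Compound 3 `CCCCCCCNc1nc2cc(-c3ccc(C)cc3)sc2c(=O)[nH]1`: 6800 nM

Compound 3 stands level with compound 2, since a 1.6-fold higher number from compound 2 to compound 3 (0.21 log units; within the scatter). The next molecule, compound 4 `Cc1ccc(-c2cc3nc(NCc4ccccc4Cl)[nH]c(=O)c3s2)cc1`, changes the group on the amine nitrogen: 2-chlorophenyl in place of hexyl on a saturated chain carbon bound to a nitrogen on an aromatic ring. In words, this is 2-chlorophenyl in place of hexyl on a saturated chain carbon bound to a nitrogen on an aromatic ring.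

Among the measured compounds shown here, three measured steps bear on this place. The first two start from the limit of compound 1: an at least 14-fold lower number from compound 1 to compound 2 (1.17 log units; beyond the scatter), and an at least 9.1-fold lower number from compound 1 to compound 3 (0.96 log units; beyond the scatter). The third, a 1.6-fold higher number from compound 2 to compound 3 (0.21 log units; within the scatter), shows no change beyond the scatter between the two longer chains. For the measured compounds named here, no measured step puts a ring in place of a chain, so these steps guide the expectation only loosely. Compound 4 keeps a sizeable group at this place, so no step beyond the scatter is expected in this assay, though the range stays wide. The expected step is a 1.0-fold higher number from compound 3 to compound 4 (0.01 log units; within the scatter). For compound 4 the estimated value is 7000 nM, with an expected range from 2500 nM to 25000 nM.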

Compound 4, half-maximal cytotoxic concentration: 32600 nM
Estimate against measurement, compound 4: 4.7-fold (0.67 log units) below; measured number above the stated range.
By their numbers in this assay, from the lowest: compounds 2 and 3 (each within the scatter of the next); then compound 4. At a limit, above all of these: compound 1.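

Compound 4 is the first compound shown with a ring at this place, on a saturated chain carbon bound to a nitrogen on an aromatic ring, and it reads as less toxic in this test than both chain compounds that give a number: a 4.8-fold higher number from compound 3 to compound 4 (0.68 log units; beyond the scatter), and a 7.8-fold higher number from compound 2 to compound 4 (0.89 log units; beyond the scatter). So the kind of group at this place matters, not only whether a sizeable group sits there, since the pentyl and heptyl amines of compound 2 and compound 3 stand level while compound 4 stands apart from both. A further step starts from a limit: an at least 1.9-fold lower number from compound 1 to compound 4 (0.28 log units; that floor lies within the scatter). Its full size cannot be read, because compound 1 gives a limit and not a number: the limit of > 62500 nM in this assay, at which 1 of the 4 values shown sits.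

As far as these compounds go, whether the ring or its chlorine carries this step stays open, and a plain benzyl group at this place would separate the two. From the compounds shown here alone, how a chlorine elsewhere on the ring, or a ring carrying an amine or a carboxylic acid instead, would read in this test also remains unknown.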